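Ethyl removal on the fused lactam core, compound 3 to 4

The compounds below may be only part of what the source reports. "The series", "measured", "known", "first", "only" and "open" are said of these compounds alone.

Compound 1 `Cc1cc(Cl)ccc1C(=O)N(C)c1cccnc1`: in an ADME assay on cells for inhibition of cytochrome P450 11B1, mitochondrial (Homo sapiens), read by HTRF (on this read-out higher numbers stand for weaker inhibition and lower numbers for stronger inhibition), compound 1 gives > 3000 nM, a limit of the assay and not a number.
Compound 2 `O=C1c2ccccc2CN1c1cccnc1`: in this assay compound 2 gives > 3000 nM, likewise a limit.
Compound 3 `CCC(=O)N[C@@H]1CCCc2c1cncc2N1C(=O)c2ccc(Cl)cc2[C@@H]1CC`: in this assay compound 3 gives 345 nM.

Among the measured compounds shown here, compound 3 is the only compound of the three with a measured number in this assay; the other two sit at the limit of > 3000 nM in this assay, at which 2 of the 3 values shown sit. For the measured compounds named here, no pair of measured compounds differs in a single place, so no measured step exists.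

Compound 4 `CCC(=O)N[C@@H]1CCCc2c1cncc2N1Cc2cc(Cl)ccc2C1=O` is drawn from compound 3 by hydrogen in place of ethyl on a saturated ring carbon. Nothing measured here speaks to what the ethyl contributes, so the direction of the step is open. The working expectation is that dropping the ethyl weakens inhibition, with a step from compound 3 to compound 4 of a 2.9-fold higher number from compound 3 to compound 4 (0.46 log units; beyond the scatter) as the estimate. For compound 4 the expected value in this assay is 1000 nM, with a range from 300 nM to 3000 nM; given that two of the three known values are limits, there is a real chance that compound 4 also returns only a limit.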

Compound 4, half-maximal inhibitory concentration: 5210 nM
For compound 4 the middle estimate is 5.2-fold (0.72 log units) below the measured one; the whole stated range lies below it.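

Among the compounds shown here, the first measured step falls on a saturated ring carbon next to the ring nitrogen, where hydrogen in place of ethyl gives a 15-fold higher number from compound 3 to compound 4 (1.18 log units; beyond the scatter) in this assay. This carbon is therefore not indifferent to its substituent: inhibition is clearly stronger with the ethyl present, and the step is large even though the group that leaves is only ethyl, with no hydrogen-bond donors, no hydrogen-bond acceptors and no net charge. The measurements shown give no cause for the size of this step.

With only ethyl and hydrogen shown on this carbon, it remains open whether methyl would recover part of the step, whether a longer chain such as propyl would go further than ethyl, whether a hydroxyl or an amine would be tolerated, and how the opposite configuration of the ethyl-bearing carbon would read. Compound 1 and compound 2 offer no number to set against this step, as each gives only a limit of the assay and differs from compound 3 in more than one place: the limit of > 3000 nM in this assay, at which 2 of the 4 values shown sit.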